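A few compounds are considered here, and "the series" means these few. Any claim that something is new, unique, unknown or untested is made for them only; others in the source may bear on it.

Series notes. The shared core is that of compound 1 `C[C@H](Nc1cc(=O)oc2cc(OCc3cccc(Cl)c3)ccc12)C(N)=O`. In an assay for inhibition of Amine oxidase [flavin-containing] B (Rattus norvegicus) (on this read-out lower numbers stand for stronger inhibition and higher numbers for weaker inhibition), compound 1 gives 210 nM. Compound 3 `NC(=O)[C@@H]1CCCN1Cc1cc(=O)oc2cc(OCc3ccccc3)ccc12` gives 380 nM in this assay, a figure within the usual scatter of that of compound 1, while compound 2 `NC(=O)[C@@H]1CCCN1c1cc(=O)oc2cc(OCc3ccccc3)ccc12` gives 16100 nM, well beyond it. Among the compounds with values here, the only step between neighbours, a 42-fold lower number from compound 2 to compound 3 (1.63 log units; beyond the scatter), concerns how the 2-carbamoylpyrrolidin-1-yl group is attached, not the group itself, and bears only loosely on the next step. Compound 4 `NNC(=O)Cc1cc(=O)oc2cc(OCc3cccc(Cl)c3)ccc12` differs from compound 1 by (aminocarbamoyl)methyl in place of (1-carbamoylethyl)amino on an aromatic carbon. Within the data shown here, no measured pair alters the amide-bearing group in this way, so no matching step size is known. Compound 4 is expected to give about 500 nM, between 120 nM and 2000 nM. The implied step, a 2.4-fold higher number from compound 1 to compound 4 (0.38 log units; beyond the scatter), is expected to be modest, at most slightly beyond the scatter toward a higher number.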

Compound 4, half-maximal inhibitory concentration: 90 nM
For compound 4 the middle estimate is 5.6-fold (0.74 log units) above the measured one; the whole stated range lies above it.
By their numbers in this assay, from the lowest: compound 4; then compounds 1 and 3 (each within the scatter of the next); then compound 2.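

In this assay, putting (aminocarbamoyl)methyl in place of (1-carbamoylethyl)amino on this aromatic carbon gives a 2.3-fold lower number from compound 1 to compound 4 (0.37 log units; beyond the scatter), so this position accepts a carbon-linked group without the defined stereocentre and without loss of inhibition. The amino link and the stereocentre of compound 1 are therefore not required for inhibition at this level. Nothing at hand gives a reason for the step.

From the compounds shown here alone, whether the terminal amino group of the new side chain contributes remains open. A plain carbamoylmethyl, a carboxylic acid or a longer chain at this position would test that.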